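From Dichlorophenyl to Fluorophenyl in a Growth Inhibitor

The source may hold more compounds than are shown below. What is called first, only, known or untested is meant among the compounds shown, and "the series" means these compounds.

Three related compounds have been tested in a functional assay on DU-145 cells (Homo sapiens) for inhibition; on this read-out higher numbers stand for weaker inhibition of growth and lower numbers for stronger inhibition of growth. Compound 1 `N#Cc1ccc(/C=C/S(=O)(=O)Cc2ccc(Nc3ncnc4ccccc34)cc2)cc1` gives only a limit of the assay, > 100000 nM, and not a number. Compound 2 `O=S(=O)(/C=C/c1ccc(Cl)cc1)Cc1ccc(Nc2ncnc3ccc(Br)cc23)cc1` gives 1000 nM. Compound 3 `COc1cc2ncnc(Nc3ccc(CS(=O)(=O)/C=C/c4ccc(Cl)cc4Cl)cc3)c2cc1OC` gives 1400 nM, so its number lies within the scatter of the value for compound 2.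

The next molecule, compound 4 `COc1cc2ncnc(Nc3ccc(CS(=O)(=O)/C=C/c4ccc(F)cc4)cc3)c2cc1OC`, keeps the core of compound 3 and changes one group: 4-fluorophenyl in place of 2,4-dichlorophenyl on a double-bonded chain carbon bound to a double-bonded chain carbon. Within the data shown here, no two measured compounds differ in just one place, so no measured step shows what this swap does in this assay. The forecast therefore rests on compound 3 at 1400 nM, and only a small move toward a higher number, not beyond the scatter, is expected. The estimated change is a 1.4-fold higher number from compound 3 to compound 4 (0.15 log units; within the scatter). The expected value for compound 4 is 2000 nM, within an estimated range of 500 nM to 10000 nM.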

Compound 4, concentration for 50% growth inhibition: > 100000 nM
Compound 4 ended at the assay's limit (the forecaster's own chance of this, stated with the estimate: 8%); at least 50-fold (1.69 log units) between middle value and limit.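

In this assay, among these compounds, the replacement of 2,4-dichlorophenyl by 4-fluorophenyl on a double-bonded chain carbon bound to a double-bonded chain carbon is the first single change that can be read, and it is large: an at least 71-fold higher number from compound 3 to compound 4 (1.85 log units; beyond the scatter). On these data alone, compound 4 gives > 100000 nM, which is a limit of the assay and not a number, so the full size of this step remains unknown. With the core of compound 3 kept, this one change is enough to bring the read-out to a value shared with another compound: the limit of > 100000 nM in this assay, at which 2 of the 4 values shown sit.

The two groups differ in both their halogens and the number of halogens, so this single step cannot show which difference matters. As far as these compounds go, how a plain phenyl or a methoxyphenyl group would behave at this position remains open.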